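Acetyl to Ethoxycarbonyl: Expectation for Compound 4

A few compounds are considered here, and "the series" means these few. Any claim that something is new, unique, unknown or untested is made for them only; others in the source may bear on it.

Measured so far in a functional assay on CCRF-SB cells (Homo sapiens) for cytotoxicity, read by MTT assay, with a stated time of 96 h; on this read-out lower numbers stand for an effect already at smaller amounts and higher numbers for an effect only at larger amounts of compound:
- compound 1 `COc1ccc(-c2[nH]c3ccc(OC)cc3c2/C=C(\C#N)S(=O)(=O)c2ccccc2)cc1`: 300 nM
- compound 2 `CC(=O)/C(=C/c1c(-c2ccccc2)[nH]c2ccccc12)C(=O)c1ccccc1`: 11000 nM
- compound 3 `COc1ccc2[nH]c(-c3ccccc3)c(/C=C(\C#N)S(=O)(=O)c3ccccc3)c2c1`: 1900 nM

Compound 2 stands at the highest number of the three; its nearest neighbour is compound 3 at 1900 nM and the furthest is compound 1 at 300 nM, both gaps beyond the scatter. Compound 4 `CCOC(=O)/C(=C/c1c(-c2ccccc2)[nH]c2ccccc12)C(=O)c1ccccc1` differs from compound 2 by ethoxy in place of methyl on a carbonyl carbon. Within the data shown here, the one measured step, a 6.3-fold higher number from compound 1 to compound 3 (0.80 log units; beyond the scatter), concerns a ring substituent on the other core and does not speak to a change on a carbonyl carbon; no measured pair covers this change. With nothing pointing either way, compound 4 is expected to show no change at the digits printed from compound 2 to compound 4 (within the scatter) relative to compound 2, nothing beyond the scatter. Compound 4 is therefore estimated at 11000 nM, within 3000 nM to 40000 nM.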

Compound 4, half-maximal effective concentration: 9600 nM
Compound 4: the middle estimate sits 1.1-fold (0.06 log units) above what was measured, and the stated range covers the measured number.
By their numbers in this assay, from the lowest: compound 1; then compound 3; then compounds 4 and 2 (each within the scatter of the next).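

In this assay, acetyl to ethoxycarbonyl on this carbonyl carbon gives a 1.1-fold lower number from compound 2 to compound 4 (0.06 log units; within the scatter), so ethoxy in place of methyl leaves the number within the scatter. Among these compounds, this is the only pair that speaks to this position, as the earlier step concerned a ring substituent on the other core. Nothing measured accounts for this result.

From the compounds shown here alone, whether an amine, a carboxylic acid or a longer alkoxy chain on this carbonyl carbon would move the number remains open. Also open, going by these compounds, is whether a methoxy on the shared core of compound 2 and compound 4 would change it.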